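This account rests on a few compounds, and the source may have more. Where it says the series, first, only, none or still open, it means among the compounds named here.

Measured compounds:
Compound 1 `O=C1C(Nc2ccccc2)=CC(=O)c2ncncc21` — in a functional assay on HCT-15 cells (Homo sapiens) for cytotoxicity, read by MTT assay, with a stated time of 72 h (a lower number here means a stronger inhibitor, a higher number a weaker inhibitor), compound 1 gives 0.01 ug/mL.
Compound 2 `O=C1C(Nc2ccc(I)cc2)=CC(=O)c2ncncc21` — compound 2 gives 0.01 ug/mL.
Compound 3 `O=C1C(Nc2ccc(Cl)cc2)=CC(=O)c2ncncc21` — compound 3 reaches only a limit of the assay, < 0.01 ug/mL.

Compound 3 therefore stands at the floor of what this assay reports; its entry is a limit and not a number (the limit of < 0.01 ug/mL in this assay, at which 1 of the 3 values shown sits). The step of a number no higher from compound 1 to compound 3 (the limit leaves the size open) and the step of a number no higher from compound 2 to compound 3 (the limit leaves the size open) are accordingly of unknown size: all that is known is that compound 3 is no weaker than compound 1 or compound 2.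

Compound 4 `Cc1ccc(NC2=CC(=O)c3ncncc3C2=O)cc1` differs from compound 3 in one place: methyl in place of chloro on an aromatic carbon.

For the measured compounds named here, no measured step exchanges chloro for methyl, so the bearing of the measured steps is indirect. The step of no change at the digits printed from compound 1 to compound 2 (within the scatter) shows that a halogen on this aromatic carbon in place of hydrogen leaves the number unchanged within the scatter, and the two steps ending at compound 3 give no readable size. Going by the values given here, nothing among the measured compounds suggests that a small group on this carbon shifts potency far in either direction.

The expectation for compound 4 is thus a step of a number no lower from compound 3 to compound 4 (the limit leaves the size open) that stays within the scatter, with the risk that compound 4 again lands at the limit. Compound 4 is estimated at 0.01 ug/mL, with a range from 0.004 ug/mL to 0.03 ug/mL.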

Compound 4, half-maximal inhibitory concentration: 0.01 ug/mL
Compound 4: middle estimate and measured number agree at the digits printed; measured number inside the range.
By their numbers in this assay, from the lowest: compounds 1, 2 and 4 (each within the scatter of the next).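

In this assay, for the compounds shown here, methyl is the first group on this aromatic carbon, para to a large group, that is neither hydrogen nor a halogen, and it gives no change at the digits printed from compound 1 to compound 4 (within the scatter). Methyl in place of iodo gives no change at the digits printed from compound 2 to compound 4 (within the scatter), so hydrogen, iodo and methyl on this carbon are not separated in this assay, and the earlier flat step from hydrogen to iodo is no longer confined to a halogen. Methyl in place of chloro gives a number no lower from compound 3 to compound 4 (the limit leaves the size open), a step that cannot be read, and neither can the other steps ending at compound 3, whose entry is a limit and not a number: the limit of < 0.01 ug/mL in this assay, at which 1 of the 4 values shown sits.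

Still open, on these data alone, is how far compound 3 lies past that limit, and so whether chloro differs at all from hydrogen, iodo or methyl on this carbon. Also open, as far as these compounds go, is whether the number holds with an amine, a carboxylic acid or a longer chain on this carbon, or with any of these groups on another carbon of the same ring.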